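The compounds below may be only part of what the source reports. "The series", "measured", "known", "first", "only" and "open" are said of these compounds alone.

Measured compounds:

compound 1, `O=S(=O)(NCCNCc1cccc2ccccc12)c1cc(C(F)(F)F)cc(C(F)(F)F)c1`: 19000 nM
compound 2, `CC(C)(C)c1ccc(CNCCCNS(=O)(=O)c2cc(C(F)(F)F)cc(C(F)(F)F)c2)cc1`: 2500 nM
compound 3, `O=S(=O)(NCCNCc1ccc(-c2ccccc2)cc1)c1cc(C(F)(F)F)cc(C(F)(F)F)c1`: 2700 nM

In a functional assay on BE(2)-C cells (Homo sapiens) for inhibition, read by MTT assay, with a stated time of 72 h (a higher number here means a weaker inhibitor of growth, a lower number a stronger inhibitor of growth), compound 2 gives 2500 nM, a number that sits at the low end of the three shown. Compound 3 gives 2700 nM in this assay, which lies within the scatter of the number for compound 2, so the two cannot be told apart. Compound 1 gives 19000 nM in this assay, a number that lies beyond the scatter above compound 2.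

Compound 4, `O=S(=O)(NCCCNCc1ccc(Cl)c(Cl)c1)c1cc(C(F)(F)F)cc(C(F)(F)F)c1`, has not yet been measured. It differs from compound 2 in one place: 3,4-dichlorophenyl in place of 4-(tert-butyl)phenyl on a saturated chain carbon bound to an amine nitrogen. For the measured compounds named here, no measured pair shows this change, so its effect is unknown from the data. The change keeps the same chain and the same sulfonamide part as compound 2, so the step of a 1.6-fold higher number from compound 2 to compound 4 (0.20 log units; within the scatter) is expected to be small and within the scatter, with no clear direction. On that basis compound 4 is estimated to give about 4000 nM in this assay, with a plausible range from 1500 nM to 11000 nM.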

Compound 4, concentration for 50% growth inhibition: 2900 nM
Compound 4: the middle estimate sits 1.4-fold (0.14 log units) above what was measured; the range from low to high includes it.
By their numbers in this assay, from the lowest: compounds 2, 3 and 4 (each within the scatter of the next); then compound 1.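

For the compounds shown here, the first step between two compounds that differ in one place reads, in this assay, a 1.2-fold higher number from compound 2 to compound 4 (0.06 log units; within the scatter). On a saturated chain carbon bound to an amine nitrogen, 3,4-dichlorophenyl and 4-(tert-butyl)phenyl therefore cannot be told apart, although one group carries chlorine and the other is all carbon. No measurement shown here accounts for this result.

The compounds shown leave open whether an unsubstituted phenyl, a 4-methoxyphenyl or a pyridine ring would give a similar number at this position. Compound 1 and compound 3 each differ from compound 2 and compound 4 in both the chain and the aromatic group, so the effect of chain length alone cannot be read from them.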